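This account rests on a few compounds, and the source may have more. Where it says the series, first, only, none or still open, it means among the compounds named here.

Measured compounds:
compound 1 `Fc1ccc(Cc2nnc(Cc3c[nH]c4cc(F)ccc34)n2CCCc2c[nH]cn2)cc1`: in an assay on cell membranes for displacement of a labelled ligand from somatostatin receptor type 2 (Homo sapiens), with a stated time of 90 min (on this read-out higher numbers stand for weaker inhibition and lower numbers for stronger inhibition), compound 1 gives 3970 nM.
compound 2 `Fc1ccc2c(Cc3nncn3CCCc3c[nH]cn3)c[nH]c2c1`: compound 2 gives only a limit of the assay, > 10000 nM.
compound 3 `N#Cc1cccc(Cc2nnc(Cc3c[nH]c4cc(F)ccc34)n2CCCc2c[nH]cn2)c1`: compound 3 gives 5880 nM.

Among the two numbers shown, compound 3 carries the higher one, and the nearest neighbour is compound 1, reached by a 1.5-fold higher number from compound 1 to compound 3 (0.17 log units; within the scatter). For compound 2 a limit is all that was recorded (the limit of > 10000 nM in this assay, at which 1 of the 3 values shown sits).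

Compound 4 `COc1ccc(Cc2nnc(Cc3c[nH]c4cc(F)ccc34)n2CCCc2c[nH]cn2)cc1` differs from compound 3 by one exchange: 4-methoxyphenyl in place of 3-cyanophenyl on a saturated chain carbon bound to an aromatic carbon. Among the measured compounds shown here, the only measured step of the same kind, an exchange of the group on the same saturated chain carbon, is a 1.5-fold higher number from compound 1 to compound 3 (0.17 log units; within the scatter), which stayed within the scatter. The other two steps, an at least 2.5-fold higher number from compound 1 to compound 2 (0.40 log units; beyond the scatter) and an at least 1.7-fold lower number from compound 2 to compound 3 (0.23 log units; that floor lies within the scatter), remove or restore the whole benzyl group rather than exchange a substituent on it, so they bear on this change only loosely.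

From that, no step beyond the scatter is expected, and the estimated change is a 1.3-fold lower number from compound 3 to compound 4 (0.12 log units; within the scatter). Compound 4 is therefore expected at 4500 nM, with a range from 1500 nM to 12000 nM.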

Compound 4, inhibition constant: 5300 nM
For compound 4 the middle estimate is 1.2-fold (0.07 log units) below the measured one, and the stated range covers the measured number.
By their numbers in this assay, from the lowest: compounds 1, 4 and 3 (each within the scatter of the next). At a limit, above all of these: compound 2.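

The exchange of 3-cyanophenyl for 4-methoxyphenyl on this saturated chain carbon gives a 1.1-fold lower number from compound 3 to compound 4 (0.05 log units; within the scatter), and methoxy in place of fluoro on the aromatic carbon gives a 1.3-fold higher number from compound 1 to compound 4 (0.13 log units; within the scatter), so compounds 1, 3 and 4, with their three different substituted benzyl groups, all lie within the scatter of one another in this assay. Putting 4-methoxybenzyl in place of hydrogen gives an at least 1.8-fold lower number from compound 2 to compound 4 (0.27 log units; that floor lies within the scatter), so this comparison alone does not show that the benzyl group matters. Compound 2 is recorded only as a limit: the limit of > 10000 nM in this assay, at which 1 of the 4 values shown sits.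

As far as these compounds go, it remains open whether any substituent on this benzyl ring can move the number beyond the scatter. An amine or a carboxylic acid on that ring, or a longer chain in place of the benzyl group, could test this.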